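Dihydropteridinone series: ring-nitrogen substituent change from benzyl to cyclopentyl

The compounds below may be only part of what the source reports. "The series", "measured", "known", "first", "only" and "open" are said of these compounds alone.

Two compounds of the series have numbers in an assay on isolated protein for inhibition of serine/threonine-protein kinase PLK1 (Homo sapiens), read by Z'-LYTE, with a stated time of 60 min; a lower number here means a stronger inhibitor, a higher number a weaker inhibitor. Compound 1 `CCOc1cc(C2CCN(C)CC2)ccc1Nc1ncc2c(n1)N(Cc1ccccc1)[C@H](CC)C(=O)N2C` gives 290 nM. Going by the values given here, compound 2 `CCOc1cc(C(=O)NC2CCN(C)CC2)ccc1Nc1ncc2c(n1)N(Cc1ccccc1)[C@H](CC)C(=O)N2C` gives 84 nM; this is the lowest of the two numbers, and the only measured step, a 3.5-fold lower number from compound 1 to compound 2 (0.54 log units; beyond the scatter), separates it from compound 1.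

Compound 3 `CCOc1cc(C(=O)NC2CCN(C)CC2)ccc1Nc1ncc2c(n1)N(C1CCCC1)[C@H](CC)C(=O)N2C` has not been measured. It differs from compound 2 in one place: cyclopentyl in place of benzyl on a nitrogen on an aromatic ring in a ring. Among the compounds with values here, the single measured step concerns the group on the aromatic carbon of the ethoxy-bearing ring, not the substituent on the ring nitrogen, so no measured step bears directly on this change, and the direction of the step to compound 3 cannot be read from the measured pair. The expectation therefore rests on the value of compound 2 alone, with a wide range around it. The step to compound 3 is expected to be a 3.4-fold lower number from compound 2 to compound 3 (0.53 log units; beyond the scatter), with the possibility of no step beyond the scatter kept open. The estimate for compound 3 in this assay is 25 nM, ranging from 4 nM to 150 nM.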

Compound 3, half-maximal inhibitory concentration: 12 nM
Estimate against measurement, compound 3: 2.1-fold (0.32 log units) above; the measured number falls inside the stated range.
By their numbers in this assay, from the lowest: compound 3; then compound 2; then compound 1.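

The ring nitrogen that bears benzyl in compound 2 proves to be a sensitive position in this assay: cyclopentyl in place of benzyl gives a 7.0-fold lower number from compound 2 to compound 3 (0.85 log units; beyond the scatter) and places compound 3 lowest of the three. This pair also shows that a six-membered aromatic ring of carbon only is not needed here for a low number, since a five-membered non-aromatic ring of carbon only gives compound 3 at 12 nM in the same assay. No measurement at hand accounts for this step, so its origin cannot be assigned to either the ring size or the loss of aromatic character.

The compounds shown leave open whether an open-chain isopropyl group, a cyclobutyl ring or a cyclohexyl ring on this nitrogen would separate ring size from the presence of a ring. Also open, on these data alone, is whether cyclopentyl gives a similar step with 1-methylpiperidin-4-yl on the aromatic carbon, or with a methyl or propyl group in place of the ethyl group on the neighbouring ring atom.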